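Replacing methoxymethyl with methoxy on the cyanophenyl ring

The source may report more compounds than this note shows. Statements on the series, on what has been measured and on what is new or still open speak of the compounds shown alone.

Of the compounds shown here, three sharing one core have been measured in a functional assay on CHO cells for inhibition of metabotropic glutamate receptor 5 (Rattus norvegicus), read by FLIPR and calcium flux; on this read-out lower numbers stand for stronger inhibition and higher numbers for weaker inhibition. The parent, compound 1 `Cc1ccc2ccc(-c3cccc(C#N)c3)cc2n1`, gives 7.7 nM. Compound 2 `Cc1ccc2ccc(-c3cc(F)cc(C#N)c3)cc2n1` gives 0.8 nM, and compound 3 `COCc1cc(C#N)cc(-c2ccc3ccc(C)nc3c2)c1` gives 2 nM. Compound 3 therefore stands second highest of the three numbers: its nearest neighbour is compound 2, with a 2.5-fold higher number from compound 2 to compound 3 (0.40 log units; beyond the scatter), and its furthest is compound 1, with a 3.9-fold lower number from compound 1 to compound 3 (0.59 log units; beyond the scatter).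

The next compound, compound 4 `COc1cc(C#N)cc(-c2ccc3ccc(C)nc3c2)c1`, differs from compound 3 in one place: methoxy in place of methoxymethyl on an aromatic carbon. For the measured compounds named here, no measured step changes this group into methoxy, so the expectation rests on the surrounding steps. Both substituents placed at this position gave lower numbers than hydrogen, a 9.6-fold lower number from compound 1 to compound 2 (0.98 log units; beyond the scatter) and a 3.9-fold lower number from compound 1 to compound 3 (0.59 log units; beyond the scatter), while the two substituted compounds differ from each other only modestly, a 2.5-fold higher number from compound 2 to compound 3 (0.40 log units; beyond the scatter). A substituent of similar size and one acceptor is thus expected to leave compound 4 close to compound 3, with any step in this assay expected to stay near or within the scatter, a 1.3-fold lower number from compound 3 to compound 4 (0.12 log units; within the scatter).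

On that basis compound 4 is estimated at 1.5 nM in this assay, within a range from 0.5 nM to 5 nM.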

Compound 4, half-maximal inhibitory concentration: 2.4 nM
Compound 4: the middle estimate sits 1.6-fold (0.20 log units) below what was measured; measured number inside the range.
By their numbers in this assay, from the lowest: compound 2; then compounds 3 and 4 (each within the scatter of the next); then compound 1.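

In this assay, the new step shows that this position, meta to a cyano group, does not separate methoxy from methoxymethyl (a 1.2-fold higher number from compound 3 to compound 4 (0.08 log units; within the scatter)), so the two ether groups cannot be told apart by this read-out. Methoxy also gives a lower number than hydrogen (a 3.2-fold lower number from compound 1 to compound 4 (0.51 log units; beyond the scatter)), making it the third group at this place to do so, with no compound among the four going against that pattern, while it stands clearly short of fluoro (a 3.0-fold higher number from compound 2 to compound 4 (0.48 log units; beyond the scatter)), so compound 2 alone holds the lowest number and neither ether group reaches it. No measurement available here explains why fluoro stands apart from the two ether groups or why all three differ from hydrogen.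

The compounds shown leave open whether the gain over hydrogen extends to an amine or a carboxylic acid at this place, or to a longer chain such as ethoxy or methoxyethyl. They also leave open whether another halogen, such as chlorine, or a trifluoromethyl group would stand with fluoro or with the two ether groups.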